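Replacing the anilino group of compound 1 with a dialkylamine

The compounds below may be only part of what the source reports. "The series", "measured", "known", "first", "only" and "open" are said of these compounds alone.

Measured compounds:
Compound 1, `O=C1C=C(Nc2cccc(Cl)c2)C(=O)c2c1nc1n2[C@H]2OC[C@@H](O)[C@H]2OC1`: 6040 nM
Compound 2, `CCCc1ccc(NC2=CC(=O)c3nc4n(c3C2=O)[C@H]2OC[C@@H](O)[C@H]2OC4)cc1`: 4990 nM
Compound 3, `CCOc1ccc(NC2=CC(=O)c3nc4n(c3C2=O)[C@H]2OC[C@@H](O)[C@H]2OC4)cc1`: 3110 nM

All three were tested in a functional assay on HeLa cells (Homo sapiens) for inhibition, read by sulforhodamine B assay; a lower number here means a stronger inhibitor, a higher number a weaker inhibitor. Compound 1 has the highest of the three numbers, but its distance to the others is small: a 1.2-fold lower number from compound 1 to compound 2 (0.08 log units; within the scatter) and a 1.9-fold lower number from compound 1 to compound 3 (0.29 log units; within the scatter), both within the scatter. Between the two para-substituted analogues, a 1.6-fold lower number from compound 2 to compound 3 (0.21 log units; within the scatter), also within the scatter. The three compounds therefore show no separation beyond the usual variation of the assay.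

Compound 4, `CCCN(CCC)C1=CC(=O)c2nc3n(c2C1=O)[C@H]1OC[C@@H](O)[C@H]1OC3`, has not yet been measured. It differs from compound 1 as follows: dipropylamino in place of (3-chlorophenyl)amino on a double-bonded ring carbon. Going by the values given here, none of the measured steps bears directly on this change: all three vary only the substituent on a phenyl ring that remains attached to the amine nitrogen, whereas here the aromatic ring itself is removed and a dipropylamino group enters. The measured steps show only that swapping substituents on that ring leaves the number within the scatter.

Among the compounds with values here, with no comparable step to lean on, compound 4 is expected to fall near the measured values or be somewhat weaker, and its estimated value is 10000 nM, with a range of 3000 nM to 40000 nM, meaning an expected step of a 1.7-fold higher number from compound 1 to compound 4 (0.22 log units; within the scatter).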

Compound 4, half-maximal inhibitory concentration: > 16000 nM
Compound 4: only a limit was reported; the forecaster's own chance of this, stated with the estimate: 20%; middle value at least 1.6-fold (0.20 log units) away from the limit.
By their numbers in this assay, from the lowest: compounds 3, 2 and 1 (each within the scatter of the next). At a limit, above all of these: compound 4.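

In this assay, going by these compounds alone, the earlier compounds varied only the substituent on a phenyl ring that stayed on the amine nitrogen, and none of those steps went beyond the scatter. Replacing the whole (3-chlorophenyl)amino group with dipropylamino is the only change shown that clearly moves the number at this position on the shared core, giving an at least 2.6-fold higher number from compound 1 to compound 4 (0.42 log units; beyond the scatter), so this position does respond to the group placed there, even though it showed no such response to substituent changes on the phenyl ring. Compound 4 gives > 16000 nM, which is a limit and not a number, and the full size of the step therefore stays unknown: the limit of > 16000 nM in this assay, at which 1 of the 4 values shown sits.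

The compounds shown leave open which part of the change matters, the aromatic ring or the amine hydrogen; compound 4 lacks both, and its two propyl chains enter at the same time. A propylamino group, which keeps the amine hydrogen without a ring, and a methyl(phenyl)amino group, which keeps the ring without that hydrogen, would separate the two.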